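The source may report more compounds than this note shows. Statements on the series, on what has been measured and on what is new or still open speak of the compounds shown alone.

Compound 3 `Cc1cc(C)c(NC(=O)N(Cc2ccc(-c3ccsc3)cc2)C2CCCCCC2)c(C)c1` is the starting point here. In a functional assay on a cell-free system (plasma) with sterol O-acyltransferase, Soat (Rattus norvegicus) as the target (on this read-out higher numbers stand for an effect only at larger amounts of compound and lower numbers for an effect already at smaller amounts), compound 3 gives 0.51 mg/kg, the highest of the two numbers reported. Compound 1 `Cc1cc(C)c(NC(=O)N(Cc2cccc(-c3cc[nH]n3)c2)C2CCCCC2)c(C)c1` in this assay gives 0.12 mg/kg. Compound 2 `O=C(Nc1c(F)cc(F)cc1F)N(Cc1ccc(-c2ccsc2)cc1)C1CCCCCC1` in this assay gives > 1 mg/kg, which is a limit of the assay rather than a number (the limit of > 1 mg/kg in this assay, at which 1 of the 3 values shown sits). Going by the values given here, the one measured step, an at least 1.9-fold lower number from compound 2 to compound 3 (0.29 log units; that floor lies within the scatter), concerns the other end of the shared core. Compound 4 `Cc1cc(C)c(NC(=O)N(Cc2ccc(-c3cnn(C)c3)cc2)C2CCCCCC2)c(C)c1` arises from compound 3 through (1-methyl-1H-pyrazol-4-yl in place of thiophen-3-yl on an aromatic carbon). Among the compounds with values here, no measured step covers this change; compound 1 also carries a pyrazolyl group and gives 0.12 mg/kg. The expected step is a 1.7-fold lower number from compound 3 to compound 4 (0.23 log units; within the scatter). For compound 4 the estimate in this assay is 0.3 mg/kg, expected between 0.1 mg/kg and 1 mg/kg.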

Compound 4, dose for half-maximal effect: 0.31 mg/kg
Compound 4: middle estimate off by 1.0-fold (0.01 log units), on the low side; low and high end bracket the measured number.
By their numbers in this assay, from the lowest: compound 1; then compounds 4 and 3 (each within the scatter of the next). At a limit, above all of these: compound 2.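

In this assay, 1-methyl-1H-pyrazol-4-yl in place of thiophen-3-yl gives a 1.6-fold lower number from compound 3 to compound 4 (0.22 log units; within the scatter) and so no change that can be told from the scatter. This position, para to a large group, thus accepts a five-membered aromatic ring with either 1 or 2 hetero atoms and keeps the number where it was. Nothing given here explains this result.

Going by these compounds, how an open-chain amine or a carboxylic acid would fare at this position remains unknown. Compound 1 differs from compound 4 in more than one place, so the two cannot be compared directly.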